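From bromo to ethoxy on an aromatic carbon

This account rests on a few compounds, and the source may have more. Where it says the series, first, only, none or still open, it means among the compounds named here.

Of the compounds shown here, two with the same core have been tested so far in a functional assay on ECa-109 cells for inhibition, with ECa-109 cell line (Homo sapiens) as the target, read by sulforhodamine B assay; on this read-out higher numbers stand for weaker inhibition and lower numbers for stronger inhibition. Compound 1 `CCCc1ccc(NC2=CC(=O)c3nc4n(c3C2=O)[C@H]2OC[C@@H](O)[C@H]2OC4)cc1` gives > 4000 nM, which is a limit and not a number. Going by the values given here, compound 2 `O=C1C=C(Nc2ccc(Br)cc2)C(=O)c2c1nc1n2[C@H]2OC[C@@H](O)[C@H]2OC1` gives 2850 nM, the only true number available, so it has no measured neighbour to be ranked against.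

The next compound, compound 3 `CCOc1ccc(NC2=CC(=O)c3nc4n(c3C2=O)[C@H]2OC[C@@H](O)[C@H]2OC4)cc1`, keeps that core and changes one place: ethoxy in place of bromo on an aromatic carbon.

Among the compounds with values here, only one measured step bears on this spot. Bromo in place of propyl gave an at least 1.4-fold lower number from compound 1 to compound 2 (0.14 log units; that floor lies within the scatter), so changing this group has not yet shown an effect clearly beyond the scatter. Ethoxy itself has not been tested here, so no direction can be firmly predicted. A step of a 1.2-fold higher number from compound 2 to compound 3 (0.09 log units; within the scatter) is therefore expected, which is no real change beyond the scatter. Compound 1 stands at the limit of > 4000 nM in this assay, at which 1 of the 2 values shown sits, so a bare limit is also possible for the new compound. For compound 3 the estimated value in this assay is 3500 nM, with an expected range from 1500 nM to 8000 nM.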

Compound 3, half-maximal inhibitory concentration: 3210 nM
Compound 3: the middle estimate sits 1.1-fold (0.04 log units) above what was measured; the range from low to high includes it.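

In this assay, going by these compounds alone, the change from 4-bromophenyl to 4-ethoxyphenyl gives a 1.1-fold higher number from compound 2 to compound 3 (0.05 log units; within the scatter), the first comparison at this position between two true numbers. Replacing one heavy atom with three and adding a hydrogen-bond acceptor therefore has no effect here beyond the scatter, so bromo and ethoxy cannot be told apart in this test. The comparison with propyl adds little, giving only an at least 1.2-fold lower number from compound 1 to compound 3 (0.09 log units; that floor lies within the scatter). Compound 1 carries a limit and not a number, so its true distance from the other two stays unknown: the limit of > 4000 nM in this assay, at which 1 of the 3 values shown sits.

The compounds shown leave open whether any group at this aromatic carbon can move the number clearly beyond the scatter, for example an amine, a carboxylic acid or a longer chain such as hexyl. They also leave open whether a group placed on a different carbon of the same six-membered aromatic ring would behave as bromo and ethoxy do here.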